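Shifting from a branched chain to a ring at the amide nitrogen

The source may hold more compounds than are shown below. What is called first, only, known or untested is meant among the compounds shown, and "the series" means these compounds.

Of the compounds shown here, two sharing one core have been measured in a functional assay on CHO-K1 cells for agonist activity at neurotensin receptor type 2 (Rattus norvegicus), read by FLIPR and calcium flux; on this read-out higher numbers stand for an effect only at larger amounts of compound and lower numbers for an effect already at smaller amounts. Compound 1 `COc1cccc(OC)c1-c1nc(C(=O)NC2(C(=O)O)CCCCC2)nc2ccc(Cl)cc12` gives 145 nM. Compound 2 `COc1cccc(OC)c1-c1nc(C(=O)N[C@@H](CC(C)C)C(=O)O)nc2ccc(Cl)cc12` gives 14 nM. The only structural difference between them is the group on the amide-type nitrogen, and the effect was a 10-fold lower number from compound 1 to compound 2 (1.02 log units; beyond the scatter). Of the two numbers, compound 2 therefore stands lowest, with compound 1 the nearest neighbour at a clearly higher value.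

Compound 3 `COc1cccc(OC)c1-c1nc(C(=O)N[C@H](C(=O)O)C2CCCCC2)nc2ccc(Cl)cc12` has not yet been measured. It differs from compound 2 in one place: cyclohexyl in place of isobutyl on a saturated chain carbon bound to an amide-type nitrogen and a carbonyl carbon. Among the compounds with values here, no measured pair shows exactly this change. Within the data shown here, the one measured step, from compound 1 to compound 2, exchanged a ring-bearing group for an open chain at the same position and was large, but in compound 3 the ring sits on a different carbon and the chain carbon itself keeps its hydrogen, so that step gives only loose guidance.

Compound 3 is expected to give 25 nM in this assay, between 6 nM and 100 nM, which would mean an estimated step of a 1.8-fold higher number from compound 2 to compound 3 (0.25 log units; within the scatter).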

Compound 3, half-maximal effective concentration: > 10 nM
Compound 3: a limit, no number; the forecaster's own chance of this, stated with the estimate: 3%; the middle value does not contradict the limit.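

In this assay compound 3 gives > 10 nM, which is a limit of the assay and not a number. Within the data shown here, no step from compound 1 or compound 2 to compound 3 can be read from it. The compounds shown leave open whether cyclohexyl in place of isobutyl on this chain carbon changes the number at all, and in which direction.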